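Where the Methyl Sits on the Methylphenyl Group

A few compounds are considered here, and "the series" means these few. Any claim that something is new, unique, unknown or untested is made for them only; others in the source may bear on it.

Compound 1 `COc1cc2c(cc1OC)C(CC(=O)O)CC2` gives 20.4% in a functional assay on the whole organism (strain Wistar) for inhibition, with Rattus norvegicus as the target, read by paw edema, with a stated time of 6 h, at a dose of 100 mg/kg; a lower number here means less inhibition, a higher number more inhibition at the dose given (going by the name of the read-out).
Compound 2 `COc1cc2c(cc1OC)C(CC(=O)Nc1ccccc1)CC2` gives 38.9%.
Compound 3 `COc1cc2c(cc1OC)C(CC(=O)Nc1cccc(C)c1)CC2` gives 38%.

Compound 3 stands second highest of the three numbers, but its gap to compound 2 is within the scatter, so the two cannot be told apart; both stand beyond the scatter above compound 1, as a number 18.5 percentage points higher from compound 1 to compound 2 (beyond the scatter) and a number 17.6 percentage points higher from compound 1 to compound 3 (beyond the scatter) show. Compound 4 `COc1cc2c(cc1OC)C(CC(=O)Nc1ccc(C)cc1)CC2` differs from compound 3 in one way: 4-methylphenyl in place of 3-methylphenyl on an amide-type nitrogen. For the measured compounds named here, the only measured step that concerns the methyl, a number 0.9 percentage points lower from compound 2 to compound 3 (within the scatter), lay within the scatter, and no measured step moves a methyl from one aromatic carbon to another. The expected step is therefore none beyond the scatter, no change at the digits printed from compound 3 to compound 4 (within the scatter), and compound 4 is estimated at 38%, within a range from 25% to 52%.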

Compound 4, a percentage reported as inhibition, in the whole organism at one dose (the size of the read-out at that dose, not a potency): 37%
Compound 4: middle estimate off by 1 percentage points, on the high side; low and high end bracket the measured number.
By their numbers in this assay, from the lowest: compound 1; then compounds 4, 3 and 2 (each within the scatter of the next).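

Moving the methyl from 3-methylphenyl to 4-methylphenyl on the amide-type nitrogen (a number 1 percentage points lower from compound 3 to compound 4 (within the scatter)) makes no difference that can be read in this assay. Compared with the unsubstituted phenyl, 4-methylphenyl also shows no readable change (a number 1.9 percentage points lower from compound 2 to compound 4 (within the scatter)), while the gain over the carboxylic acid remains (a number 16.6 percentage points higher from compound 1 to compound 4 (beyond the scatter)). No measurement here accounts for these numbers.

The compounds shown leave open what a chloro, methoxy or amine group on this aromatic ring would do. Also open, from the compounds shown here alone, is whether benzyl in place of the methylphenyl group would hold that gain.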